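The source may hold more compounds than are shown below. What is called first, only, known or untested is meant among the compounds shown, and "the series" means these compounds.

Compound 1 `COc1ccc(C(=O)Nc2nc(-c3cc(OC)c(OC)c(OC)c3)cs2)cc1`: > 25000 nM
Compound 2 `Cc1s/c(=N\C(=O)c2ccccc2)n(C)c1-c1ccccc1`: 197 nM

These two compounds have been tested in a functional assay on MDA-MB-231 cells (Homo sapiens), read by microscopy and transwell migration, with a stated time of 24 h; on this read-out lower numbers stand for stronger inhibition and higher numbers for weaker inhibition. Compound 1 reads > 25000 nM, which is a limit of the assay and not a number. Going by the values given here, that leaves compound 2, at 197 nM, as the only true number available, so its standing can be judged against no other measured value.

Compound 3 `Cc1s/c(=N\C(=O)c2ccccc2)n(C)c1-c1ccc(F)cc1` is compound 2 with a single change: fluoro in place of hydrogen on an aromatic carbon. Put plainly, a phenyl becomes a 4-fluorophenyl. Among the compounds with values here, no measured pair of compounds shows what this replacement does here, so the expectation rests on compound 2 at 197 nM. No clear direction is expected, and the estimated step of a 1.1-fold lower number from compound 2 to compound 3 (0.04 log units; within the scatter) should stay within the usual scatter. For compound 3 the expected value is 180 nM, with an estimated range of 60 nM to 600 nM.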

Compound 3, half-maximal inhibitory concentration: 847 nM
Compound 3: middle estimate off by 4.7-fold (0.67 log units), on the low side; the whole stated range lies below it.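

In this assay, the aromatic carbon para to a large group on the phenyl of compound 2 proves sensitive to substitution: fluoro in place of hydrogen, a change of a single heavy atom, gives a 4.3-fold higher number from compound 2 to compound 3 (0.63 log units; beyond the scatter). The change weakens inhibition without abolishing it, since compound 3 still gives a true number, 847 nM, and not a limit of the assay. Nothing measured among the compounds shown accounts for this loss.

The compounds shown leave open whether the loss is particular to fluoro or extends to other groups at this carbon, such as chloro, an amine or a carboxylic acid. With only one replacement at this position, they also leave open whether any group there can match or better the hydrogen of compound 2.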